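Replacing the 4-ethylpiperazin-1-yl group of compound 3

The compounds below may be only part of what the source reports. "The series", "measured", "known", "first", "only" and "open" are said of these compounds alone.

compound 1 `CC(C)N1CCN(c2cccc3c2C[C@H](CN(C)[C@H]2CCCc4cccnc42)NC3)CC1`: 56.6%
compound 2 `CN(C[C@H]1Cc2c(cccc2N2CCN3CCC[C@@H]3C2)CN1)[C@H]1CCCc2cccnc21`: 52.2%
compound 3 `CCN1CCN(c2cccc3c2C[C@H](CN(C)[C@H]2CCCc4cccnc42)NC3)CC1`: 0%

In an ADME assay on microsomes from liver (Homo sapiens) for metabolic stability, read by LC-MS, with a stated time of 10 min (a higher number here means that more of the compound is left, a lower number that less of the compound is left), compound 3 gives 0%, the lowest of the three numbers. Compound 4 `CN(C[C@H]1Cc2c(cccc2N2C[C@@H]3C[C@H]2CN3)CN1)[C@H]1CCCc2cccnc21` keeps the shared core and changes one group on an aromatic carbon: a group of 7 heavy atoms (5 carbon, 2 nitrogen; 2 five-membered non-aromatic rings with 1 hetero atom each) in place of a group of 8 heavy atoms (6 carbon, 2 nitrogen; one six-membered non-aromatic ring with 2 hetero atoms), on an aromatic carbon. Within the data shown here, no measured step makes this exact change, so the evidence is indirect. Two steps that end at compound 3 are large: a number 56.6 percentage points lower from compound 1 to compound 3 (beyond the scatter) and a number 52.2 percentage points lower from compound 2 to compound 3 (beyond the scatter). The groups of the other two compounds, by contrast, give nearly the same result: a number 4.4 percentage points lower from compound 1 to compound 2 (within the scatter). In these three compounds, then, only the 4-ethylpiperazin-1-yl group goes with the very low number. That is a thin basis, and the entering group has not been measured here. A large rise in this assay is still the likelier outcome, though its size is uncertain. The expected change is a number 45 percentage points higher from compound 3 to compound 4 (beyond the scatter). Compound 4 is estimated at 45%, with an expected range from 15% to 75%.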

Compound 4, percent of the compound remaining: 100%
Estimate against measurement, compound 4: 55 percentage points below; measured number outside the range, above it.
By their numbers in this assay, from the lowest: compound 3; then compounds 2 and 1 (each within the scatter of the next); then compound 4.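

At this aromatic carbon, this assay shows the entering group doing more than escaping the very low number of the 4-ethylpiperazin-1-yl group: the change gives a number 100 percentage points higher from compound 3 to compound 4 (beyond the scatter). It also separates two groups that had looked alike from a third, with a number 47.8 percentage points higher from compound 2 to compound 4 (beyond the scatter) and a number 43.4 percentage points higher from compound 1 to compound 4 (beyond the scatter). The earlier compounds shown here therefore understated what this position allows, and compound 4 now stands highest of the four.

Nothing shown explains this result. The entering group differs from the 4-ethylpiperazin-1-yl group at once in its rings, its defined stereocentres and its hydrogen-bond donor, which leaves open which of these matters, and how a morpholin-4-yl group, or the entering group with a methyl on its ring nitrogen, would compare.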